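Swapping methylsulfanyl for methoxy on a benzyl amine

This account rests on a few compounds, and the source may have more. Where it says the series, first, only, none or still open, it means among the compounds named here.

Measured compounds:
- compound 1, `CSc1ccc(CNc2nc(SC)nc3ncccc23)cc1`: 14800 nM
- compound 2, `C[Se]c1nc([Se]C)c2cccnc2n1`: "not determined" (no result reported)

Among the measured compounds shown here, in a functional assay on HTB-54 cells (Homo sapiens) for cytotoxicity, read by MTT assay, with a stated time of 72 h (a higher number here means a weaker inhibitor of growth, a lower number a stronger inhibitor of growth), compound 1 gives 14800 nM, the only number in hand, since compound 2 carries no result there. Compound 3, `COc1ccc(CNc2nc(SC)nc3ncccc23)cc1`, differs from compound 1 by methoxy in place of methylsulfanyl on an aromatic carbon. For the measured compounds named here, no step between measured compounds is available to calibrate this change, so the expectation rests on compound 1 alone. The change is small and keeps the count of hydrogen-bond acceptors, so for compound 3 a step no larger than the scatter is expected, a 1.0-fold higher number from compound 1 to compound 3 (0.01 log units; within the scatter). Compound 3 is estimated at 15000 nM, between 6000 nM and 40000 nM.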

Compound 3, concentration for total growth inhibition: > 100000 nM
Compound 3 gave a limit, no number; the forecaster's own chance of this, stated with the estimate: 10%; middle value at least 6.6-fold (0.82 log units) away from the limit.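

In this assay, this place para to a large group proves sensitive: methoxy in place of methylsulfanyl gives an at least 6.7-fold higher number from compound 1 to compound 3 (0.82 log units; beyond the scatter), although the swap leaves the counts of heavy atoms and hydrogen-bond acceptors unchanged. Exchanging sulfur for oxygen here is thus enough to weaken growth inhibition beyond the usual scatter. Compound 3 gives a limit and not a number: the limit of > 100000 nM in this assay, at which 1 of the 3 values shown sits.

The full size of the step stays open, and a single pair cannot give its cause. Also open, from the compounds shown here alone, is how an amine, a chlorine atom or a longer chain such as ethylsulfanyl would behave at this place.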